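Expected Cytotoxicity After a Methyl-to-Fluoro Swap

The source may report more compounds than this note shows. Statements on the series, on what has been measured and on what is new or still open speak of the compounds shown alone.

Compound 1, `Cc1c(C(=O)/C=C/c2ccc(Cl)c(Cl)c2)[n+]([O-])c2ccccc2[n+]1[O-]`: 13000 nM
Compound 2, `Cc1ccc(/C=C/C(=O)c2c(C)[n+]([O-])c3ccccc3[n+]2[O-])cc1`: 40000 nM

Both were measured in an ADME assay on HPC cells (Homo sapiens) for cytotoxicity, with a stated time of 48 h; on this read-out lower numbers stand for higher toxicity in this test and higher numbers for lower toxicity in this test. Among the measured compounds shown here, compound 2 holds the higher of the two numbers; the only measured step is a 3.1-fold higher number from compound 1 to compound 2 (0.49 log units; beyond the scatter), which lies beyond the scatter.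

Compound 3, `Cc1c(C(=O)/C=C/c2ccc(F)cc2)[n+]([O-])c2ccccc2[n+]1[O-]`, differs from compound 2 by fluoro in place of methyl on an aromatic carbon. For the measured compounds named here, no measured step swaps these two groups, so that single step on the same ring is only a rough guide. A small move toward the number of compound 1 seems plausible, yet within the scatter is also possible. Compound 3 is therefore expected to give about 28000 nM, with a range from 10000 nM to 80000 nM. That estimate means an expected 1.4-fold lower number from compound 2 to compound 3 (0.15 log units; within the scatter).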

Compound 3, half-maximal cytotoxic concentration: 48000 nM
Beside the measured number, compound 3's estimate is 1.7-fold (0.23 log units) below it; the measured number falls inside the stated range.
By their numbers in this assay, from the lowest: compound 1; then compounds 2 and 3 (each within the scatter of the next).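

In this assay the swap from 4-methylphenyl to 4-fluorophenyl brings a 1.2-fold higher number from compound 2 to compound 3 (0.08 log units; within the scatter) and so does not separate these two groups at this place. The swap from 3,4-dichlorophenyl to 4-fluorophenyl brings a 3.7-fold higher number from compound 1 to compound 3 (0.57 log units; beyond the scatter) and so gives a second step clear of the scatter, again starting at compound 1. Nothing available here explains either step.

From the compounds shown here alone, whether an amine or a methoxy group on this ring would move the number beyond the scatter stays open. So does which of the two chlorines of compound 1 goes with its lower number.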